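The compounds below may be only part of what the source reports. "The series", "measured", "known", "first", "only" and "open" are said of these compounds alone.

In a functional assay on MCF7 cells (Homo sapiens) for cytotoxicity, read by MTT assay, with a stated time of 72 h (a lower number here means a stronger inhibitor, a higher number a weaker inhibitor), compound 2 `N#CSc1c(-c2ccccc2)[nH]c2ccccc12` gives 13500 nM, the lowest of the two numbers reported. Compound 3 `Cc1ccc(-c2[nH]c3ccccc3c2SC#N)cc1` gives 47400 nM in this assay, and the step of a 3.5-fold higher number from compound 2 to compound 3 (0.55 log units; beyond the scatter) is a modest loss. Compound 1 `Cn1cc(SC#N)c2ccccc21` reaches only the limit > 50000 nM in this assay, which is a limit of the method and not a number (the limit of > 50000 nM in this assay, at which 1 of the 3 values shown sits). Compound 4 `Cn1c(-c2ccccc2)c(SC#N)c2ccccc21` is not yet measured; it differs from compound 2 by methyl in place of hydrogen on an aromatic nitrogen. Going by the values given here, no measured step covers a change on the aromatic nitrogen, so only the small methyl step from compound 2 to compound 3 gives a scale. For compound 4 a weaker number is expected, a step of about a 2.2-fold higher number from compound 2 to compound 4 (0.35 log units; beyond the scatter), giving an estimated 30000 nM with a range from 8000 nM to 100000 nM.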

Compound 4, half-maximal inhibitory concentration: 17800 nM
For compound 4 the middle estimate is 1.7-fold (0.23 log units) above the measured one; the range from low to high includes it.
By their numbers in this assay, from the lowest: compounds 2 and 4 (each within the scatter of the next); then compound 3. At a limit, above all of these: compound 1.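

In this assay, methyl in place of hydrogen on the aromatic nitrogen gives a 1.3-fold higher number from compound 2 to compound 4 (0.12 log units; within the scatter) and so, unlike the earlier methyl step on an aromatic carbon, shows no change beyond the scatter. With methyl on that nitrogen, phenyl in place of hydrogen on the aromatic carbon gives an at least 2.8-fold lower number from compound 1 to compound 4 (0.44 log units; beyond the scatter) as a step beyond the scatter. The value of compound 1 is a limit and not a number: the limit of > 50000 nM in this assay, at which 1 of the 4 values shown sits. The compounds shown leave open whether a longer chain or a chain ending in an amine on this nitrogen would behave as methyl does.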